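A few compounds are considered here, and "the series" means these few. Any claim that something is new, unique, unknown or untested is made for them only; others in the source may bear on it.

Compound 1 `Cn1nc(-c2ccc(Cl)cc2)n(C)c1=S` is the starting point of this comparison. Among the compounds with values here, in a functional assay on the whole organism with Mus musculus as the target (on this read-out lower numbers stand for an effect already at smaller amounts and higher numbers for an effect only at larger amounts of compound), compound 1 gives 0.27 mg/kg, the lowest of the three numbers measured so far. Compound 2 `CCCn1c(-c2ccc(Cl)cc2)nn(C)c1=S` gives 12.5 mg/kg, and compound 3 `CCn1nc(-c2ccc(Cl)cc2)n(C)c1=S` gives 100 mg/kg. Both of those steps are large: a 46-fold higher number from compound 1 to compound 2 (1.67 log units; beyond the scatter) and a 370-fold higher number from compound 1 to compound 3 (2.57 log units; beyond the scatter), each arising from ethyl or methyl in place of hydrogen on a saturated chain carbon bound to an aromatic nitrogen.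

Compound 4 `Cc1ccc(-c2nn(C)c(=S)n2C)cc1` changes a different place. Here (methyl in place of chloro on an aromatic carbon), on an aromatic carbon of a six-membered aromatic ring of carbon only, para to a group of 8 heavy atoms. Within the data shown here, no measured step touches this ring position, so the two known steps, both on the saturated chain carbon, do not bear directly on it. Without any guide for this position, the expectation for compound 4 is a step of a 1.5-fold higher number from compound 1 to compound 4 (0.17 log units; within the scatter), within the scatter. Compound 4 is therefore estimated at 0.4 mg/kg, in a range from 0.1 mg/kg to 2 mg/kg.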

Compound 4, dose for half-maximal effect: 4.2 mg/kg
For compound 4 the middle estimate is 11-fold (1.02 log units) below the measured one, and the stated range ends below it.
By their numbers in this assay, from the lowest: compound 1; then compound 4; then compound 2; then compound 3.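

Within the data shown here, the ring position had no measured step before, and it proves far from silent: in this assay, methyl in place of chloro on this aromatic carbon gives a 16-fold higher number from compound 1 to compound 4 (1.19 log units; beyond the scatter). So the outcome depends on the group on this six-membered ring as well as on the saturated chain carbon bound to an aromatic nitrogen, even though chloro and methyl each count as one heavy atom, with no hydrogen-bond donors or acceptors. No measurement available here accounts for the size of this step.

The compounds shown carry only chloro or methyl at this ring position, so it remains open how fluoro, methoxy or trifluoromethyl would fare there. A single swap also cannot tell whether chloro is unusually favourable here or whether other groups would give numbers close to that of methyl.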